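From Chloro to Bromo on an Aromatic Carbon

The source may report more compounds than this note shows. Statements on the series, on what has been measured and on what is new or still open speak of the compounds shown alone.

In a functional assay on P388 cells (Mus musculus) for inhibition (on this read-out lower numbers stand for stronger inhibition and higher numbers for weaker inhibition), compound 1 (`O=C1CCCCC/C1=C\c1ccccc1`) gives only a limit of > 50000 nM and not a number.

Among the measured compounds shown here, compound 2 (`O=C1CCCCC/C1=C\c1ccc(Cl)cc1`) gives 19100 nM as the only true number so far, so there is no second number to rank it against. For the measured compounds named here, the one measured step is an at least 2.6-fold lower number from compound 1 to compound 2 (0.41 log units; beyond the scatter) and it comes with chloro in place of hydrogen on an aromatic carbon.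

Compound 3 (`O=C1CCCCC/C1=C\c1ccc(Br)cc1`) carries bromo in place of chloro on an aromatic carbon and nothing else changes. The measured step bears on this change only loosely: it puts a group where hydrogen stood, while here one group is swapped for another. Going by the values given here, no measured pair makes this swap. Starting from compound 2 at 19100 nM as the anchor, no step beyond the scatter is expected in this assay for this swap. The estimate amounts to a 1.1-fold lower number from compound 2 to compound 3 (0.05 log units; within the scatter) as the expected step. The expected value for compound 3 is 17000 nM with an estimated range of 8000 nM to 38000 nM around it.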

Compound 3, half-maximal inhibitory concentration: 16800 nM
Compound 3: the middle estimate sits 1.0-fold (0.01 log units) above what was measured, and the stated range covers the measured number.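

In this assay, putting bromo in place of chloro on this aromatic carbon gives a 1.1-fold lower number from compound 2 to compound 3 (0.06 log units; within the scatter), so the two halogens cannot be told apart at this position on the strength of these numbers. Bromo in place of hydrogen gives an at least 2.9-fold lower number from compound 1 to compound 3 (0.47 log units; beyond the scatter), which means that a second halogen at the same place, para to a group of 9 heavy atoms, also goes with a step beyond the scatter, something the single chloro step could not show on its own. The true size of both steps away from compound 1 stays unknown, because compound 1 gives a limit and not a number: the limit of > 50000 nM in this assay, at which 1 of the 3 values shown sits.

The compounds shown carry only hydrogen, chloro or bromo at this place, and so they cannot tell whether a halogen is needed for the step or whether another group would serve as well. As far as these compounds go, how fluoro, a methoxy group, an amine or a carboxylic acid at this place would read in this assay stays open, as does the effect of a halogen elsewhere on the ring.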